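Bromo to Methyl on the Aryl Ring of Compound 3

The source may report more compounds than this note shows. Statements on the series, on what has been measured and on what is new or still open speak of the compounds shown alone.

Compound 1 `CC(=O)Oc1ccc(/C=C/C(=O)OCCCSc2nc(-c3ccc(S(N)(=O)=O)cc3)n(-c3ccc(F)cc3)n2)cc1OC(C)=O`: 10900 nM
Compound 2 `CC(=O)Oc1ccc(/C=C/C(=O)NCCCSc2nc(-c3ccc(S(C)(=O)=O)cc3)n(-c3ccc(Br)cc3)n2)cc1OC(C)=O`: 16400 nM
Compound 3 `COc1cc(/C=C/C(=O)OCCSc2nc(-c3ccc(S(C)(=O)=O)cc3)n(-c3ccc(Br)cc3)n2)ccc1OC(C)=O`: 12400 nM

All three values come from a functional assay on B16-F10 cells (Mus musculus) for antiproliferative activity, read by MTT assay, with a stated time of 72 h; a lower number here means a stronger inhibitor, a higher number a weaker inhibitor. Compound 3 stands second highest of the three numbers, yet its gaps to compound 1 and to compound 2 both lie within the scatter, so no order among the three can be read. Compound 4 `COc1cc(/C=C/C(=O)OCCSc2nc(-c3ccc(S(C)(=O)=O)cc3)n(-c3ccc(C)cc3)n2)ccc1OC(C)=O` differs from compound 3 by methyl in place of bromo on an aromatic carbon. Going by the values given here, no step between measured compounds shows this change, and the measured values themselves do not separate. The step is therefore expected to be a 1.0-fold higher number from compound 3 to compound 4 (0.02 log units; within the scatter), in no direction beyond the scatter. Compound 4 is estimated at 13000 nM, with a range from 6000 nM to 28000 nM.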

Compound 4, half-maximal inhibitory concentration: 15300 nM
Beside the measured number, compound 4's estimate is 1.2-fold (0.07 log units) below it; measured number inside the range.
By their numbers in this assay, from the lowest: compounds 1, 3, 4 and 2 (each within the scatter of the next).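

In this assay, going by these compounds alone, the change from 4-bromophenyl to 4-methylphenyl gives a 1.2-fold higher number from compound 3 to compound 4 (0.09 log units; within the scatter), the first direct reading at this position, where the earlier compounds offered no step. Exchanging bromo for methyl here, with the rest of the molecule held fixed, therefore leaves the number within the scatter. The compounds shown offer no measured reason for this outcome. On these data alone, it remains open what an amine or a carboxylic acid in this place would give, and whether the same exchange reads alike on a longer chain.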